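Working notes: chloro-bearing thiophene step, compound 3 to compound 4

The source may report more compounds than this note shows. Statements on the series, on what has been measured and on what is new or still open speak of the compounds shown alone.

The series shares one core and varies the aromatic group on a carbon with a double bond to nitrogen. Compound 1 `Cc1csc(C2=NNC(c3ccc(N4CCCCC4)cc3)C2)c1` carries 4-methylthiophen-2-yl, and in an ADME assay on CCRF-CEM cells (Homo sapiens) for cytotoxicity, with a stated time of 5 days (on this read-out higher numbers stand for weaker inhibition and lower numbers for stronger inhibition), compound 1 gives 16300 nM. Compound 2 `Cc1ccc(C2=NNC(c3ccc(N4CCCCC4)cc3)C2)s1` carries 5-methylthiophen-2-yl; in this assay compound 2 gives 15300 nM, and the step of a 1.1-fold lower number from compound 1 to compound 2 (0.03 log units; within the scatter) is within the scatter. Compound 3 `Clc1ccc(C2=NNC(c3ccc(N4CCCCC4)cc3)C2)s1` carries 5-chlorothiophen-2-yl. For compound 3 this assay reports only a limit, > 100000 nM, so compound 3 stands at the top edge of the numbers shown (the limit of > 100000 nM in this assay, at which 1 of the 3 values shown sits). The two steps that lead into it, an at least 6.1-fold higher number from compound 1 to compound 3 (0.78 log units; beyond the scatter) and an at least 6.5-fold higher number from compound 2 to compound 3 (0.81 log units; beyond the scatter), both run to weaker inhibition and both lie beyond the scatter.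

Compound 4 `Clc1cc(C2=NNC(c3ccc(N4CCCCC4)cc3)C2)c(Cl)s1` is not yet measured. The change is 2,5-dichlorothiophen-3-yl in place of 5-chlorothiophen-2-yl on a carbon with a double bond to nitrogen. Both measured steps that touch compound 3 show that chloro in place of methyl on an aromatic carbon moves the number up; compound 4 keeps chloro and adds a second one, so no return toward the numbers of compound 1 or compound 2 is expected. The step expected in this assay, a number no higher from compound 3 to compound 4 (the limit leaves the size open), is none beyond the scatter. Compound 4 is expected to sit at the limit again, estimated at 100000 nM with a range from 30000 nM to 300000 nM.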

Compound 4, half-maximal inhibitory concentration: 37700 nM
Estimate against measurement, compound 4: 2.7-fold (0.42 log units) above; low and high end bracket the measured number.
By their numbers in this assay, from the lowest: compounds 2 and 1 (each within the scatter of the next); then compound 4. At a limit, above all of these: compound 3.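

In this assay, replacing 5-chlorothiophen-2-yl with 2,5-dichlorothiophen-3-yl on the carbon with a double bond to nitrogen brings the number back down, an at least 2.6-fold lower number from compound 3 to compound 4 (0.42 log units; beyond the scatter), so chloro on the thiophene does not by itself hold a compound at the limit. The return is only partial, since the two methylthiophene compounds are not reached again: the steps are a 2.5-fold higher number from compound 2 to compound 4 (0.39 log units; beyond the scatter) and a 2.3-fold higher number from compound 1 to compound 4 (0.36 log units; beyond the scatter), and both lie beyond the scatter. Compound 3 remains a limit and not a number, so the step out of it has a lower bound but no fixed size: the limit of > 100000 nM in this assay, at which 1 of the 4 values shown sits.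

This change moves the attachment from thiophen-2-yl to thiophen-3-yl and adds a second chloro in a single step, so the compounds shown do not separate the two changes. Also open, on these data alone, is how this assay would read with an amine, a carboxylic acid or a longer chain on the thiophene in place of chloro or methyl.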